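A few compounds are considered here, and "the series" means these few. Any claim that something is new, unique, unknown or untested is made for them only; others in the source may bear on it.

Compound 1 `COc1ccc2c(=O)c(/C=C/C(=O)Nc3cccc(Cl)c3)coc2c1`: > 100000 nM
Compound 2 `COc1ccc2c(=O)c(/C=C/C(=O)Nc3cc(C)ccc3C)coc2c1`: 11100 nM
Compound 3 `COc1ccc2c(=O)c(/C=C/C(=O)Nc3ccccc3OC)coc2c1`: 32300 nM

In a functional assay on Huh-7 cells (Homo sapiens) for inhibition, read by MTT assay, with a stated time of 48 h (on this read-out lower numbers stand for stronger inhibition and higher numbers for weaker inhibition), compound 1 gives only a limit of the assay, > 100000 nM, so no number is known for it. Compound 1 thus stands at the limit of > 100000 nM in this assay, at which 1 of the 3 values shown sits. Compound 4 `COc1ccc2c(=O)c(/C=C/C(=O)Nc3ccc(C)cc3)coc2c1` differs from compound 1 by 4-methylphenyl in place of 3-chlorophenyl on an amide-type nitrogen. Two measured steps start from compound 1 and change the same group on the same amide-type nitrogen: an at least 9.0-fold lower number from compound 1 to compound 2 (0.95 log units; beyond the scatter) and an at least 3.0-fold lower number from compound 1 to compound 3 (0.49 log units; beyond the scatter). Both gave lower numbers, beyond the scatter. The change to 4-methylphenyl is of the same kind, so a lower number is expected, though its size is uncertain since compound 1 shows only a limit. For compound 4 the expected step is an at least 2.5-fold lower number from compound 1 to compound 4 (0.39 log units; beyond the scatter). Compound 4 is estimated at 40000 nM, between 10000 nM and 150000 nM.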

Compound 4, half-maximal inhibitory concentration: > 100000 nM
Compound 4: a limit, no number (the forecaster's own chance of this, stated with the estimate: 35%); middle value at least 2.5-fold (0.39 log units) away from the limit.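

In this assay, compound 4 with its 4-methylphenyl group gives only a limit, and the step from compound 1 cannot be read because both ends are limits. Moving to 4-methylphenyl still loses ground against the other two groups on the amide-type nitrogen: there is an at least 3.0-fold higher number from compound 3 to compound 4 (0.49 log units; beyond the scatter) and an at least 9.0-fold higher number from compound 2 to compound 4 (0.95 log units; beyond the scatter). Methyl on the phenyl ring is therefore not enough for a measurable value, as the 2,5-dimethylphenyl of compound 2 gives one and 4-methylphenyl does not, and compound 4 now joins compound 1 at the ceiling: the limit of > 100000 nM in this assay, at which 2 of the 4 values shown sit.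

The compounds shown leave open how a 2-methylphenyl group alone would compare with 2,5-dimethylphenyl. They also leave open whether a benzyl group on this nitrogen would give a measurable value.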